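Opening the Ring on the Amide Nitrogen: Lipophilicity Outlook

The source may report more compounds than this note shows. Statements on the series, on what has been measured and on what is new or still open speak of the compounds shown alone.

Of the compounds shown here, three sharing one core have been measured in a physicochemical assay for lipophilicity; a lower number here means a more polar compound, a higher number a more lipophilic compound. Compound 1 `O=C(NC1(C(=O)NO)CCC1)c1ccc(C#Cc2ccccc2)cc1` reaches only a limit of that assay, reported as > 3. Its standing is therefore known only as the limit of > 3 in this assay, at which 1 of the 3 values shown sits, not as a number. Compound 2 `O=C(NC1(C(=O)NO)CCS(=O)(=O)CC1)c1ccc(C#Cc2ccccc2)cc1` gives 3 in this assay. Compound 3 `O=C(NC1(C(=O)NO)CCNCC1)c1ccc(C#Cc2ccccc2)cc1` gives 3 in this assay. Among the compounds with values here, no pair of measured compounds differs in a single place, so nothing among the three can be read as a step in either direction.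

Compound 4 `O=C(N[C@@H](CO)C(=O)NO)c1ccc(C#Cc2ccccc2)cc1` has not yet been measured. It differs from compound 1 in one place: a group of 7 heavy atoms (3 carbon, 1 nitrogen, 3 oxygen; no ring) in place of a group of 8 heavy atoms (5 carbon, 1 nitrogen, 2 oxygen; one four-membered non-aromatic ring of carbon only), on an amide-type nitrogen. Within the data shown here, with no measured step to lean on, the move is expected to run downward, toward the more polar end, by an amount beyond the usual scatter, estimated at a number at least 0.70 log units lower from compound 1 to compound 4 (beyond the scatter). Compound 4 is accordingly expected to give about 2.3 in this assay, with a range from 1.6 to 3.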

Compound 4, distribution coefficient: 2
For compound 4 the middle estimate is 0.30 log units above the measured one, within the range that was stated.
By their numbers in this assay, from the lowest: compound 4; then compounds 2 and 3 (each within the scatter of the next).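

Within the data shown here, compound 4 gives the first readable step at this position, on the amide-type nitrogen: in this assay, replacing the 1-(hydroxycarbamoyl)cyclobutyl group with an open group that has no ring and 1 defined stereocentre gives a number at least 1.00 log units lower from compound 1 to compound 4 (beyond the scatter). The entering group of compound 4 counts 3 hydrogen-bond donors and 3 hydrogen-bond acceptors against 2 of each in the group it replaces, so the step comes with more than one change at once. The step is a bound and not an exact size, because the reading for compound 1 is a limit of the assay: the limit of > 3 in this assay, at which 1 of the 4 values shown sits.

Which part of the exchange carries the step stays open, as the loss of the ring and the gain of the hydroxyl arrive together. Going by these compounds, how a longer chain, an amine or a carboxylic acid at this place would read in this assay also remains unknown.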